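Aryl substituent of the shared core: compound 3 to compound 4

The source may hold more compounds than are shown below. What is called first, only, known or untested is meant among the compounds shown, and "the series" means these compounds.

Three analogues of the shared core have been measured in a functional assay on CHO-K1 cells for antagonist activity at adenosine receptor A1 (Homo sapiens), read by a beta-galactosidase reporter and cAMP accumulation, with stated times of 15 min and 6 h; a lower number here means a stronger inhibitor, a higher number a weaker inhibitor. Compound 1 `Cc1nc(-c2nc(N)c3cc(Cc4ccccc4)sc3n2)cs1` gives 263 nM, compound 2 `Nc1nc(-c2ccccc2)nc2sc(Cc3ccccc3)cc12` gives 151 nM, and compound 3 `N#Cc1cccc(-c2nc(N)c3cc(Cc4ccccc4)sc3n2)c1` gives 222 nM. On the numbers as they read, compound 3 has the second highest of the three, but the step of a 1.2-fold lower number from compound 1 to compound 3 (0.07 log units; within the scatter) and the step of a 1.5-fold higher number from compound 2 to compound 3 (0.17 log units; within the scatter) are both within the scatter, as is a 1.7-fold lower number from compound 1 to compound 2 (0.24 log units; within the scatter), so the three substituents are not separated.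

Compound 4 `Nc1nc(-c2ccccn2)nc2sc(Cc3ccccc3)cc12` is not yet measured. The change is pyridin-2-yl in place of 3-cyanophenyl on an aromatic carbon. Among the compounds with values here, the steps that bear on it are the exchanges of one aromatic substituent for another at the same place, namely a 1.7-fold lower number from compound 1 to compound 2 (0.24 log units; within the scatter), a 1.2-fold lower number from compound 1 to compound 3 (0.07 log units; within the scatter) and a 1.5-fold higher number from compound 2 to compound 3 (0.17 log units; within the scatter), none of which goes beyond the scatter. Replacing one six-membered aromatic ring of carbon only by one six-membered aromatic ring with 1 hetero atom is therefore expected to give no step beyond the scatter in this assay. Compound 4 is expected to show a 1.1-fold lower number from compound 3 to compound 4 (0.02 log units; within the scatter) and is estimated at 210 nM, with a range from 80 nM to 550 nM.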

Compound 4, inhibition constant: 3710 nM
For compound 4 the middle estimate is 18-fold (1.25 log units) below the measured one; measured number outside the range, above it.
By their numbers in this assay, from the lowest: compounds 2, 3 and 1 (each within the scatter of the next); then compound 4.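

In this assay, this aromatic carbon of the shared core does not accept every aromatic substituent alike: the three earlier groups stay within the scatter of each other, while pyridin-2-yl separates from all of them, with a 25-fold higher number from compound 2 to compound 4 (1.39 log units; beyond the scatter), a 17-fold higher number from compound 3 to compound 4 (1.22 log units; beyond the scatter) and a 14-fold higher number from compound 1 to compound 4 (1.15 log units; beyond the scatter). The first of these steps is the closest exchange, one six-membered aromatic ring with 1 hetero atom in place of one of carbon only, yet nitrogen in the substituent does not by itself go with the higher number, as compound 1 and compound 3 also carry it. Nothing available accounts for the size of these steps.

Open, going by these compounds, is whether the result depends on where the ring nitrogen stands, which pyridin-3-yl and pyridin-4-yl at the same carbon would show. Also open, on these data alone, is whether an aromatic ring is needed here at all, which piperidin-1-yl would address.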